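Swapping chloro for dimethylamino on a cinnamoyl thiazole amide

A few compounds are considered here, and "the series" means these few. Any claim that something is new, unique, unknown or untested is made for them only; others in the source may bear on it.

Measured compounds:
compound 1, `Cc1nc(NC(=O)c2ccccc2)sc1C(=O)/C=C/c1ccc(Cl)cc1`, 63.7%
compound 2, `COc1ccc(C(=O)Nc2nc(C)c(C(=O)/C=C/c3ccc(C)cc3)s2)cc1`, 100%

Of the compounds shown here, two have been measured in an assay for inhibition of Polyunsaturated fatty acid 5-lipoxygenase (Homo sapiens), read by spectrophotometry, tested at 10 uM, in the presence of a further agent that is not named here; on this read-out lower numbers stand for less inhibition and higher numbers for more inhibition at the one concentration tested (going by the name of the read-out). Compound 1 gives 63.7%, the lower of the two numbers. Compound 2 gives 100%, which lies beyond the usual scatter above compound 1. Compound 2 differs from compound 1 in more than one place, so no single step can be read from that pair.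

Compound 3, `Cc1nc(NC(=O)c2ccccc2)sc1C(=O)/C=C/c1ccc(N(C)C)cc1`, has not been measured. It differs from compound 1 by dimethylamino in place of chloro on an aromatic carbon. Among the measured compounds shown here, no measured pair shows this change, so the expected step of a number 6.3 percentage points higher from compound 1 to compound 3 (within the scatter) is small, and likely within the scatter. Compound 3 is estimated at 70%, with a range from 40% to 95%.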

Compound 3, a percentage reported as inhibition, at one concentration (the size of the read-out at that concentration, not a potency): 88.2%
Beside the measured number, compound 3's estimate is 18.2 percentage points below it; measured number inside the range.
By their numbers in this assay, from the lowest: compound 1; then compound 3; then compound 2.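

In this assay, dimethylamino in place of chloro on the aromatic carbon gives a number 24.5 percentage points higher from compound 1 to compound 3 (beyond the scatter). Among the compounds shown here, this is the first single change that can be read, and it shows that this position accepts a group of three heavy atoms in place of one while inhibition rises. No measurement here explains the rise. Still open, as far as these compounds go, is whether the nitrogen or the two methyl groups matter more, which a plain amine or a morpholine at the same position could help to separate.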